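The source may report more compounds than this note shows. Statements on the series, on what has been measured and on what is new or still open speak of the compounds shown alone.

Of the compounds shown here, two sharing one core have been measured so far in a functional assay on MCF7 cells (Homo sapiens) for antiproliferative activity, read by MTT assay, with a stated time of 48 h; a lower number here means a stronger inhibitor, a higher number a weaker inhibitor. Compound 1 `COC(=O)CN(C)c1nc(Nc2ccc(Cl)cc2)ncc1[N+](=O)[O-]` gives 60700 nM. Compound 2 `COC(=O)CN(C)c1nc(NCc2ccccc2)ncc1[N+](=O)[O-]` gives 85900 nM, the higher of the two numbers, yet the step of a 1.4-fold higher number from compound 1 to compound 2 (0.15 log units; within the scatter) lies within the scatter, so on these figures the two compounds cannot be told apart. Compound 3 `CCOC(=O)CNc1nc(NCc2ccccc2)ncc1[N+](=O)[O-]` is the compound still to be measured. It differs from compound 2 in one place: ((ethoxycarbonyl)methyl)amino in place of ((methoxycarbonyl)methyl)(methyl)amino on an aromatic carbon. Among the measured compounds shown here, the single measured step exchanged a group in a different part of the core, not the group changed here, so no measured step bears directly on the present change, and there is no basis for expecting a shift in either direction. The expectation for compound 3 is therefore a step of a 1.0-fold higher number from compound 2 to compound 3 (0.00 log units; within the scatter), meaning no step beyond the scatter. For the measured compounds named here, compound 3 is estimated in this assay at 86000 nM, with a range from 30000 nM to 250000 nM, kept wide because no directly comparable pair exists among the measured compounds.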

Compound 3, half-maximal inhibitory concentration: 52400 nM
Compound 3: middle estimate off by 1.6-fold (0.22 log units), on the high side; the range from low to high includes it.
By their numbers in this assay, from the lowest: compounds 3, 1 and 2 (each within the scatter of the next).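

In this assay, this first measured change at the aromatic carbon ortho to the nitro group gives a 1.6-fold lower number from compound 2 to compound 3 (0.21 log units; within the scatter), so on these figures the two compounds cannot be told apart. The change rearranges the same atoms into a different side chain: ((ethoxycarbonyl)methyl)amino has 1 hydrogen-bond donor where ((methoxycarbonyl)methyl)(methyl)amino has 0, and at this position that exchange produces no step beyond the scatter. No measurement is available that could explain this result.

The change also alters two things at once, the methyl on the nitrogen and the methyl ester that becomes an ethyl ester, so the shown compounds cannot separate the contribution of either edit, and a compound carrying only one of them would be needed to do so. Also open, from the compounds shown here alone, is whether anything other than an ester at the end of this side chain, such as a carboxylic acid or an amide, or a longer chain between the nitrogen and the carbonyl, would move the number beyond the scatter.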